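This account rests on a few compounds, and the source may have more. Where it says the series, first, only, none or still open, it means among the compounds named here.

Going by the values given here, compound 1 `COc1cc(CNC(=O)CCCCCCC(C)C)ccc1OC(=O)CCC(=O)Oc1ccc(C(N)=S)cc1` and compound 2 `COc1cc(CNC(=O)CCCCCCC(C)C)ccc1OCCCCCOc1ccc(-c2cc(=S)ss2)cc1` are the two members measured so far. In a functional assay on HeLa cells (Homo sapiens) for antiproliferative activity, read by MTT assay, with a stated time of 48 h (on this read-out higher numbers stand for weaker inhibition and lower numbers for stronger inhibition), compound 1 gives only a limit, > 50000 nM, not a number. In this assay compound 2 likewise gives only a limit, > 50000 nM. Both readings therefore rest at the limit of > 50000 nM in this assay, at which 2 of the 2 values shown sit, so compound 2 stands at the edge of what the read-out resolves and cannot be set apart from compound 1. Compound 3 `COc1cc(CNC(=O)CCCC/C=C/C(C)C)ccc1OCCCCCOc1ccc(-c2cc(=S)ss2)cc1` is not yet measured. It differs from compound 2 in one place: 3-methylbut-1-en-1-yl in place of isopentyl on a saturated chain carbon, four bonds along the chain from a carbonyl carbon. Among the compounds with values here, no measured step covers this change, and the two values at hand are limits, so no direction can be read from them. The expected step in this assay is a step that the limit leaves unreadable from compound 2 to compound 3, none beyond the scatter, with a limit again the likelier outcome. For compound 3 the estimate in this assay is 60000 nM, within 20000 nM to 200000 nM.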

Compound 3, half-maximal inhibitory concentration: > 50000 nM
Compound 3: only a limit was reported; the forecaster's own chance of this, stated with the estimate: 80%; the middle value is on the limit's open side.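

No step can be read between compound 2 and compound 3 in this assay, since both readings are limits, not numbers: the limit of > 50000 nM in this assay, at which 3 of the 3 values shown sit.

The compounds shown leave open whether 3-methylbut-1-en-1-yl in place of isopentyl has any effect, and whether any member of this series gives a numerical value in this assay.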